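Dropping One Chlorine Atom: What Compound 4 May Show

The compounds below may be only part of what the source reports. "The series", "measured", "known", "first", "only" and "open" are said of these compounds alone.

Compound 1, with the structure `Cc1ccc(-c2nn(-c3cccc(Cl)c3)cc2C(=O)Nc2ccc(C)c(S(=O)(=O)N3CCOCC3)c2)cc1`, is the starting point here. In an assay on isolated protein for antagonist activity at Bile acid receptor (Homo sapiens), read by TR-FRET, with a stated time of 20 min (a higher number here means a weaker inhibitor, a lower number a stronger inhibitor), compound 1 gives 10.4 nM, the lowest of the three numbers in hand. Compound 2, `COc1cccc(Cn2cc(C(=O)Nc3ccc(C)c(S(=O)(=O)N4CCOCC4)c3)c(-c3cccc(OC)c3)n2)c1`, is the nearest neighbour: in this assay compound 2 gives 42.8 nM, a gap that lies beyond the usual scatter of repeated measurements. Compound 3, `Cc1ccc(NC(=O)c2cnn(-c3ccccc3)c2C(F)(F)F)cc1S(=O)(=O)N1CCOCC1`, stands furthest away, since in this assay compound 3 gives 996 nM, again clearly beyond the scatter. Compounds 2 and 3 differ from compound 1 in several places at once, so they show only where compound 1 sits, not what any single change does.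

Compound 4, `Cc1ccc(-c2nn(-c3ccccc3)cc2C(=O)Nc2ccc(C)c(S(=O)(=O)N3CCOCC3)c2)cc1`, is the not-yet-measured partner of compound 1. Among the measured compounds shown here, the one change is hydrogen in place of chloro on an aromatic carbon; seen one bond further out, a 3-chlorophenyl becomes a plain phenyl. For the measured compounds named here, no measured pair in this set isolates such a change, so the expectation rests on the general experience that taking away a single chloro usually costs a little potency. The step from compound 1 to compound 4 is therefore estimated as a 2.4-fold higher number from compound 1 to compound 4 (0.38 log units; beyond the scatter), a modest rise that may or may not clear the scatter. Compound 4 is expected to give about 25 nM, within a range from 8 nM to 80 nM.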

Compound 4, half-maximal inhibitory concentration: 47 nM
Compound 4: the middle estimate sits 1.9-fold (0.27 log units) below what was measured; measured number inside the range.
By their numbers in this assay, from the lowest: compound 1; then compounds 2 and 4 (each within the scatter of the next); then compound 3.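

Among the compounds shown here, this is the first pair in the set that differs in one place only, so the chloro on the 3-chlorophenyl can now be judged on its own: in this assay, putting hydrogen in its place gives a 4.5-fold higher number from compound 1 to compound 4 (0.66 log units; beyond the scatter). A single chlorine atom at this position therefore makes a modest but real difference to the number. The chloro is not required for activity, though, since compound 4 with its plain phenyl still gives 47 nM, and nothing in the data explains why the number rises when the chlorine is removed.

The compounds shown compare only chloro and hydrogen at this one position, so it remains open whether a fluoro, a bromo, a methyl or a nitrile there would match chloro, fall back towards hydrogen or go beyond both. As far as these compounds go, it is also open whether the same exchange would give a step of similar size on a different core, since this single pair cannot show how far the result carries.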